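Dropping the methyl: compound 3 to compound 4

The source may report more compounds than this note shows. Statements on the series, on what has been measured and on what is new or still open speak of the compounds shown alone.

In a functional assay on A549 cells (Homo sapiens) for inhibition (a lower number here means a stronger inhibitor, a higher number a weaker inhibitor), compound 1 `O=C1C=CC(OCC(F)(F)F)N1c1ccc(C(F)(F)F)cc1` gives 8390 nM, compound 2 `O=C1C=CC(OCC(F)(F)F)N1c1cc(F)cc(F)c1` gives 5000 nM and compound 3 `Cc1ccc(N2C(=O)C=CC2OCC(F)(F)F)cc1` gives 13700 nM. Compound 3 and compound 1 lie within the scatter of each other at the top of this range, and compound 2 has the lower number. Compound 4 `O=C1C=CC(OCC(F)(F)F)N1c1ccccc1` follows from compound 3 by hydrogen in place of methyl on an aromatic carbon. For the measured compounds named here, the one measured step at this place is a 1.6-fold higher number from compound 1 to compound 3 (0.21 log units; within the scatter), methyl in place of trifluoromethyl, and it stays within the scatter. No step beyond the scatter is therefore expected in this assay. The expectation is a 1.2-fold lower number from compound 3 to compound 4 (0.10 log units; within the scatter). Compound 4 is estimated at 11000 nM, with an expected range of 5500 nM to 22000 nM.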

Compound 4, half-maximal inhibitory concentration: 23400 nM
Compound 4: the middle estimate sits 2.1-fold (0.33 log units) below what was measured; the measured number lies above the stated range.
By their numbers in this assay, from the lowest: compounds 2, 1, 3 and 4 (each within the scatter of the next, the first and the last beyond it).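

In this assay, hydrogen in place of methyl gives a 1.7-fold higher number from compound 3 to compound 4 (0.23 log units; within the scatter), so these two groups cannot be told apart on this aromatic carbon, para to a large group. Hydrogen in place of trifluoromethyl at the same place gives a 2.8-fold higher number from compound 1 to compound 4 (0.45 log units; beyond the scatter), a modest step but the first at this position beyond the scatter. No evidence on the origin of this step is available.

Open, from the compounds shown here alone, is how a methoxy group, an amine or a nitrile at this carbon would compare. Also open, going by these compounds, is whether the trifluoromethyl step would hold with other changes to the shared core.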